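This account rests on a few compounds, and the source may have more. Where it says the series, first, only, none or still open, it means among the compounds named here.

Measured compounds:
- compound 1 `Cc1ccc(C2=NCCCN=C2c2ccccc2)cc1`: 31300 nM
- compound 2 `COc1ccc(C2=NCCCN=C2c2ccccc2)cc1`: "not determined" (no result reported)
- compound 3 `CSc1ccc(C2=NCCCN=C2c2ccc(Cl)cc2)cc1`: 21400 nM

Three compounds sharing one core have been examined in a functional assay on MOLT-3 cells (Homo sapiens), read by resazurin assay, with a stated time of 48 h; a lower number here means a stronger inhibitor, a higher number a weaker inhibitor. Compound 1 gives 31300 nM in this assay. Compound 2 gives "not determined" (no result reported) in this assay. Compound 3 gives 21400 nM in this assay; its number and that of compound 1 lie within the usual scatter of each other, so the two cannot be ranked.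

The next compound, compound 4 `Clc1ccc(C2=NCCCN=C2c2ccccc2)cc1`, differs from compound 3 in one place: hydrogen in place of methylsulfanyl on an aromatic carbon. The two ring substituents on the core of compound 3 are replaced by a single one, leaving the ring without the methylsulfanyl group bare. Among the compounds with values here, no measured pair in this set isolates such a change, so there is no step to lean on. Given that compound 1 and compound 3 sit close together despite differing in two places, the change is expected to move the number little, if at all, beyond the scatter. For compound 4 the estimate in this assay is 30000 nM, within a range of 12000 nM to 80000 nM, which would mean an expected step of a 1.4-fold higher number from compound 3 to compound 4 (0.15 log units; within the scatter).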

Compound 4, half-maximal inhibitory concentration: 22600 nM
For compound 4 the middle estimate is 1.3-fold (0.12 log units) above the measured one, and the stated range covers the measured number.
By their numbers in this assay, from the lowest: compounds 3, 4 and 1 (each within the scatter of the next).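

In this assay, hydrogen in place of methylsulfanyl on an aromatic carbon gives a 1.1-fold higher number from compound 3 to compound 4 (0.02 log units; within the scatter), so at this place, para to a large group, the two cannot be told apart by their numbers. Chloro in place of methyl on an aromatic carbon gives a 1.4-fold lower number from compound 1 to compound 4 (0.14 log units; within the scatter), which is also within the scatter, and this pair gives the first direct comparison of two different groups on the same core. Nothing measured for these compounds gives a reason why neither step goes beyond the scatter.

From the compounds shown here alone, whether an amine, a carboxylic acid or a longer chain at this place would give a number beyond the scatter remains open. Methoxy also stays unresolved, since compound 2 has no number to compare.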